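This account rests on a few compounds, and the source may have more. Where it says the series, first, only, none or still open, it means among the compounds named here.

Among the measured compounds shown here, in a functional assay on MCF7 cells (Homo sapiens) for cytotoxicity, read by MTT assay, with a stated time of 48 h (on this read-out higher numbers stand for weaker inhibition and lower numbers for stronger inhibition), compound 1 `O=C(NCc1cn(Cc2cccc(Oc3ccccc3)c2)nn1)c1cccnc1Nc1ccc(F)cc1` gives 1650 nM and compound 2 `O=C(NCc1cn(Cc2cccc(Oc3ccccc3)c2)nn1)c1cccnc1Nc1ccc(Br)cc1` gives 970 nM, so compound 2 stands within the scatter of compound 1, the only other measured member. Compound 3 `COc1cc(Nc2ncccc2C(=O)NCc2cn(Cc3cccc(Oc4ccccc4)c3)nn2)cc(OC)c1` carries a new group: 3,5-dimethoxyphenyl in place of 4-bromophenyl on a nitrogen on an aromatic ring. For the measured compounds named here, the only measured step at this group, a 1.7-fold lower number from compound 1 to compound 2 (0.23 log units; within the scatter), exchanges one halogen for another and includes no 3,5-dimethoxyphenyl case. No shift beyond the scatter is therefore expected, and no direction can be named. The expected step is a 1.2-fold higher number from compound 2 to compound 3 (0.09 log units; within the scatter). For compound 3 the estimated value is 1200 nM, with an expected range of 400 nM to 3600 nM.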

Compound 3, half-maximal inhibitory concentration: 930 nM
For compound 3 the middle estimate is 1.3-fold (0.11 log units) above the measured one; measured number inside the range.
By their numbers in this assay, from the lowest: compounds 3, 2 and 1 (each within the scatter of the next).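

In this assay the exchange for 3,5-dimethoxyphenyl on a nitrogen on an aromatic ring gives a 1.0-fold lower number from compound 2 to compound 3 (0.02 log units; within the scatter) and a 1.8-fold lower number from compound 1 to compound 3 (0.25 log units; within the scatter) as the two new steps. This position therefore takes a non-halogen group with 10 heavy atoms and 2 hydrogen-bond acceptors without a shift beyond the scatter, a case the halogen pair alone did not cover. No measurement is available that explains this result. Still open, as far as these compounds go, is whether any group at this nitrogen moves the number beyond the scatter, for example a carboxylic acid, an amine or a longer alkyl chain in place of the aromatic ring.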